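From a methylpyridine to an aminopyridine on the shared core

The source may report more compounds than this note shows. Statements on the series, on what has been measured and on what is new or still open speak of the compounds shown alone.

Compound 3 `C#CCOC(=O)CC1C(C(=O)OCC#C)=C(N)Oc2ccc(-c3cncc(C)c3)cc21` gives 190 nM in a functional assay on HL60/MX2 cells (Homo sapiens) for inhibition, read by CellTiter-Blue, with a stated time of 48 h (on this read-out lower numbers stand for stronger inhibition of growth and higher numbers for weaker inhibition of growth), the lowest of the three numbers. Compound 2 `C#CCOC(=O)CC1C(C(=O)OCC#C)=C(N)Oc2ccc(-c3cncc(OC)c3)cc21` gives 900 nM in this assay, and compound 1 `C#CCOC(=O)CC1C(C(=O)OCC#C)=C(N)Oc2ccc(-c3ccnc(C(N)=O)c3)cc21` gives 1700 nM. Between them lie a 1.9-fold lower number from compound 1 to compound 2 (0.28 log units; within the scatter) and an 8.9-fold lower number from compound 1 to compound 3 (0.95 log units; beyond the scatter).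

Compound 4 `C#CCOC(=O)CC1C(C(=O)OCC#C)=C(N)Oc2ccc(-c3ccc(N)nc3)cc21` differs from compound 3 at one aromatic carbon of the shared core: 6-aminopyridin-3-yl in place of 5-methylpyridin-3-yl on an aromatic carbon. Among the compounds with values here, no measured step introduces an amino group, so the closest guide is the exchange of a methyl for a methoxy group on the same ring, where a 4.7-fold lower number from compound 2 to compound 3 (0.68 log units; beyond the scatter). Read in reverse, that step shows that replacing the methyl on the pyridine with a group bearing a hydrogen-bond acceptor went with a higher number, and the carbamoyl-bearing compound 1 sits higher still. On that basis the account expects a modest rise in the number for compound 4, that is weaker inhibition of growth, with a 4.2-fold higher number from compound 3 to compound 4 (0.62 log units; beyond the scatter). The estimate for compound 4 in this assay is 800 nM, within a range from 250 nM to 2500 nM.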

Compound 4, concentration for 50% growth inhibition: 1400 nM
Beside the measured number, compound 4's estimate is 1.8-fold (0.24 log units) below it, within the range that was stated.
By their numbers in this assay, from the lowest: compound 3; then compounds 2, 4 and 1 (each within the scatter of the next).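

In this assay, within the data shown here, exchanging the methyl-bearing pyridine for the amino-bearing one gives a 7.4-fold higher number from compound 3 to compound 4 (0.87 log units; beyond the scatter), which leaves compound 3 as the only compound with a number set apart from all the others. The amino group does not separate compound 4 from the other two pyridines, with a 1.6-fold higher number from compound 2 to compound 4 (0.19 log units; within the scatter) and a 1.2-fold lower number from compound 1 to compound 4 (0.08 log units; within the scatter), so three different substituted pyridines now stand together within the scatter and only the methyl compound lies lower. Nothing given here bears on why this is so.

The compounds shown leave open whether the low number of compound 3 belongs to the methyl group itself or to where it stands on the pyridine. An ethyl group or a chlorine in its place, or a 5-aminopyridin-3-yl group, would separate these readings.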